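The source may report more compounds than this note shows. Statements on the series, on what has been measured and on what is new or still open speak of the compounds shown alone.

Measured so far:
compound 1 `CO[C@H]1C(=O)N2C(C(=O)C(C)(C)C)=C(C)[C@@H](Sc3nnnn3C)S(=O)(=O)C12` — 18 h
compound 2 `CO[C@H]1C(=O)N2C(C(=O)C(C)(C)C)=C(C)[C@@H](Sc3ccccn3)S(=O)(=O)C12` — 24 h
compound 3 `CO[C@H]1C(=O)N2C(C(=O)OC(C)(C)C)=C(CSc3ccccn3)CS(=O)(=O)C12` — 5.1 h

The read-out is a physicochemical assay, at pH 7.4; on this read-out higher numbers stand for a longer-lived compound and lower numbers for a shorter-lived compound. Among the three measured compounds, compound 3 gives the lowest number, and its gaps to compound 1 and to compound 2 are both beyond the scatter. How the core of compound 3 differs from the core of compound 2 is not broken down here.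

One change is seen twice. From compound 2 to compound 1 it reads (1-methyl-1H-tetrazol-5-yl in place of pyridin-2-yl on a sulfur), and the step it made was a 1.3-fold lower number from compound 2 to compound 1 (0.12 log units; within the scatter). From compound 3 to compound 4 `CO[C@H]1C(=O)N2C(C(=O)OC(C)(C)C)=C(CSc3nnnn3C)CS(=O)(=O)C12`, not yet measured, it reads (1-methyl-1H-tetrazol-5-yl in place of pyridin-2-yl on a sulfur). The surroundings differ: in compound 2 the sulfur's other neighbour is a saturated ring carbon, in compound 3 a saturated chain carbon, so this is the same kind of change, not the same change.

For compound 4 the expected step is a 1.1-fold lower number from compound 3 to compound 4 (0.05 log units; within the scatter), resting on a 1.3-fold lower number from compound 2 to compound 1 (0.12 log units; within the scatter), which lay within the scatter. Compound 4 is therefore estimated at 4.5 h, with a likely range from 2.5 h to 8 h.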

Compound 4, half-life: 3.8 h
Estimate against measurement, compound 4: 1.2-fold (0.07 log units) above; the measured number falls inside the stated range.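

In this assay, 1-methyl-1H-tetrazol-5-yl in place of pyridin-2-yl on a sulfur gives a 1.3-fold lower number from compound 3 to compound 4 (0.13 log units; within the scatter), and the same kind of change on the other core gave a 1.3-fold lower number from compound 2 to compound 1 (0.12 log units; within the scatter). Both steps lie within the scatter, so across these two cores the change carries over only as one with no readable effect; this does not show that a step beyond the scatter would carry over, nor that other cores would behave alike. Nothing available explains the result or the agreement between the two steps.

Open, going by these compounds, is whether another group on the sulfur, such as a phenyl ring bearing a carboxylic acid or an amine, would move this assay beyond the scatter on either core.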